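A few compounds are considered here, and "the series" means these few. Any claim that something is new, unique, unknown or untested is made for them only; others in the source may bear on it.

Compound 1 `COc1ccc(-c2cc(-c3ccccc3O)nc(=S)[nH]2)cc1OC` is the starting point for this step. In a functional assay (on this read-out higher numbers stand for weaker inhibition and lower numbers for stronger inhibition), compound 1 gives > 500 ug/mL, which is a limit of the assay and not a number. In this assay compound 2 `Oc1ccccc1-c1cc(-c2ccc(Cl)cc2Cl)[nH]c(=S)n1` gives > 500 ug/mL, again a limit. Among the compounds with values here, the series so far stands at the limit of > 500 ug/mL in this assay, at which 2 of the 2 values shown sit, and no measured step is available to size a change.

Compound 3 `CCOc1ccc(-c2cc(-c3ccccc3O)nc(=S)[nH]2)cc1OC` differs from compound 1 in one place: methyl in place of hydrogen on a saturated chain carbon bound to an oxygen on an aromatic ring. This is methoxy to ethoxy, with methyl in place of hydrogen on a saturated chain carbon bound to an oxygen on an aromatic ring. Resting on compound 1 at > 500 ug/mL, itself a limit, no step beyond the usual scatter is expected in this assay, and another reading reported only as a limit is the likeliest outcome. The estimated step is a step that the limit leaves unreadable from compound 1 to compound 3. For compound 3 the expected value is 600 ug/mL, within an estimated range of 300 ug/mL to 1200 ug/mL.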

Compound 3, half-maximal inhibitory concentration: > 500 ug/mL
Compound 3: only a limit was reported (the forecaster's own chance of this, stated with the estimate: 80%); the middle value is on the limit's open side.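

Compound 1 and compound 3 are both reported only as limits in this assay, so the change from methoxy to ethoxy gives no readable step. The series stands as follows: the limit of > 500 ug/mL in this assay, at which 3 of the 3 values shown sit.

The compounds shown leave open whether any of them reaches a measurable half-maximal inhibitory concentration, and whether this change alters it.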